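This account rests on a few compounds, and the source may have more. Where it says the series, first, only, none or still open, it means among the compounds named here.

Measured so far, in a functional assay on the whole organism (strain Albino) with Mus musculus as the target, with a stated time of 4 h; on this read-out higher numbers stand for an effect only at larger amounts of compound and lower numbers for an effect already at smaller amounts:
compound 1 `COc1ccc(-c2cc(-c3ccc(F)cc3)nc(NC(=O)N/N=C\c3cccc(Cl)c3)n2)cc1OC` gives 300 mg/kg
compound 2 `COc1ccc(-c2cc(-c3ccc(Cl)cc3)nc(NC(=O)N/N=C\c3ccc([N+](=O)[O-])cc3)n2)cc1OC` gives 100 mg/kg

Of the two compounds, compound 2 has the lowest number in this assay, so its effect appears already at the smaller amount. Its nearest neighbour is compound 1, whose number is higher by a margin that lies beyond the usual scatter of such measurements.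

The next compound, compound 3 `COc1ccc(-c2cc(-c3ccc(Cl)cc3)nc(NC(=O)N/N=C\c3cccc(Cl)c3)n2)cc1OC`, has not yet been measured. It differs from compound 2 in one place: 3-chlorophenyl in place of 4-nitrophenyl on a carbon with a double bond to nitrogen. The group that enters is the same 3-chlorophenyl group that compound 1 carries, while the rest of compound 3 is that of compound 2. Among the compounds with values here, no measured pair shows exactly this exchange on its own, so its effect can only be estimated from the two numbers at hand. The expectation is that compound 3 sits between compound 2 and compound 1, with a modest rise in number, roughly at the edge of the scatter, expected as a 2.0-fold higher number from compound 2 to compound 3 (0.30 log units; within the scatter). Compound 3 is therefore estimated at 200 mg/kg, with a likely range from 100 mg/kg to 400 mg/kg.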

Compound 3, dose for half-maximal effect: 300 mg/kg
For compound 3 the middle estimate is 1.5-fold (0.18 log units) below the measured one; the range from low to high includes it.
By their numbers in this assay, from the lowest: compound 2; then compounds 1 and 3 (each within the scatter of the next).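

In this assay, putting 3-chlorophenyl in place of 4-nitrophenyl on a carbon with a double bond to nitrogen gives a 3.0-fold higher number from compound 2 to compound 3 (0.48 log units; beyond the scatter), so with the rest of the molecule unchanged, this position responds to the group it carries, and the effect appears at the smaller amount with 4-nitrophenyl. Within the data shown here, the exchange of chloro in place of fluoro on an aromatic carbon gives no change at the digits printed from compound 1 to compound 3 (within the scatter), so of the two single exchanges now available, only the one at the carbon with a double bond to nitrogen moves the number beyond the usual scatter. Nothing measured here explains why the step at this position occurs.

The compounds shown leave open whether that step depends on the nitro group itself or on where the substituent sits on the phenyl ring, a question that 3-nitrophenyl and 4-chlorophenyl at the same place could help separate. They also leave open how an amine such as 4-aminophenyl would behave there, and whether chloro and fluoro would still give matching numbers alongside 4-nitrophenyl.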